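The source may hold more compounds than are shown below. What is called first, only, known or untested is meant among the compounds shown, and "the series" means these compounds.

Three compounds share one core, each carrying a different group on the carbonyl carbon of the amide at the front. Compound 1 is `N#Cc1cccc(C(=O)Nc2ccc3nc(NC(=O)C4CCCCC4)sc3c2)c1`; in a functional assay on WI-38 VA13 cells (Homo sapiens) for cytotoxicity (on this read-out higher numbers stand for an effect only at larger amounts of compound and lower numbers for an effect already at smaller amounts), compound 1 gives 0.52 ug/mL. Compound 2 is `COc1ccc(C(=O)Nc2ccc3nc(NC(=O)C4CCCCC4)sc3c2)cc1`, and in this assay compound 2 gives 4.9 ug/mL. Compound 3 is `O=C(Nc1ccc2nc(NC(=O)C3CCCCC3)sc2c1)c1c(F)cccc1C(F)(F)F`, and in this assay compound 3 gives 0.032 ug/mL. On these numbers compound 1 stands second highest of the three: compound 2 is nearest, with a higher number, and compound 3 is furthest, with a lower one.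

Compound 4 is `Cn1nccc1C(=O)Nc1ccc2nc(NC(=O)C3CCCCC3)sc2c1`. It differs from compound 1 in one place: 1-methyl-1H-pyrazol-5-yl in place of 3-cyanophenyl on a carbonyl carbon.

For the measured compounds named here, only one measured step changes the same place, a 9.4-fold higher number from compound 1 to compound 2 (0.97 log units; beyond the scatter), where the 4-methoxyphenyl group in place of the 3-cyanophenyl group raised the number well beyond the scatter. The 1-methyl-1H-pyrazol-5-yl group is another departure from the 3-cyanophenyl group, so a step of a broadly similar kind, towards a higher number, is expected, though with wide uncertainty since no other heteroaryl group has been measured here. The expected step is a 5.8-fold higher number from compound 1 to compound 4 (0.76 log units; beyond the scatter). Compound 4 is therefore estimated at 3 ug/mL, within a range from 0.6 ug/mL to 15 ug/mL.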

Compound 4, half-maximal effective concentration: 0.58 ug/mL
Estimate against measurement, compound 4: 5.2-fold (0.71 log units) above; measured number below the stated range.
By their numbers in this assay, from the lowest: compound 3; then compounds 1 and 4 (each within the scatter of the next); then compound 2.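

In this assay, replacing the 3-cyanophenyl group with the smaller 1-methyl-1H-pyrazol-5-yl group gives a 1.1-fold higher number from compound 1 to compound 4 (0.05 log units; within the scatter), so on this carbonyl carbon neither the six-membered carbon ring nor the triple bond of compound 1 is needed to keep the number where it stands. The same group in place of 4-methoxyphenyl gives an 8.4-fold lower number from compound 2 to compound 4 (0.93 log units; beyond the scatter), which shows that moving away from the 3-cyanophenyl group does not by itself raise the number, as the one earlier step might have suggested, and that compound 2 is the one set apart among these three. Nothing measured here explains why these two very different groups match while the 4-methoxyphenyl group does not.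

Going by these compounds, it remains open whether a plain phenyl or a pyridine ring would also match compound 1 and compound 4, and whether the methyl on the pyrazole matters, which the unsubstituted pyrazole would test. A non-aromatic group on the same carbonyl carbon, such as a piperidine ring or a short ethyl chain, would show whether an aromatic ring is needed there at all.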